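Swapping the Aryl Group on the Alkenyl Side Chain

The compounds below may be only part of what the source reports. "The series", "measured", "known", "first", "only" and "open" are said of these compounds alone.

Compounds measured so far:
compound 1 `O[C@@H](c1ccccc1)[C@H]1CO[C@H](c2ccccc2)[C@@H](C/C=C/c2ccccn2)C1`: 33800 nM
compound 2 `O[C@@H](c1ccccc1)[C@H]1CO[C@H](c2ccccc2)[C@@H](C/C=C/C2CCCCC2)C1`: 6440 nM
compound 3 `COc1cccc(/C=C/C[C@H]2C[C@@H]([C@@H](O)c3ccccc3)CO[C@@H]2c2ccccc2)c1`: 10900 nM

Of the compounds shown here, three sharing one core have been measured in a functional assay on HeLa cells (Homo sapiens) for cytotoxicity, read by WST assay, with a stated time of 48 h; a higher number here means a weaker inhibitor, a lower number a stronger inhibitor. Compound 1 gives the highest number of the three in this assay. Compound 3 stands second highest of the three numbers in this assay; its nearest neighbour is compound 2, with a 1.7-fold higher number from compound 2 to compound 3 (0.23 log units; within the scatter), and its furthest is compound 1, with a 3.1-fold lower number from compound 1 to compound 3 (0.49 log units; beyond the scatter).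

The step now considered leads from compound 3 to compound 4 `O=[N+]([O-])c1ccc(/C=C/C[C@H]2C[C@@H]([C@@H](O)c3ccccc3)CO[C@@H]2c2ccccc2)cc1`, which is not yet measured. The change is 4-nitrophenyl in place of 3-methoxyphenyl on a double-bonded chain carbon bound to a double-bonded chain carbon.

Of the measured steps, a 5.2-fold lower number from compound 1 to compound 2 (0.72 log units; beyond the scatter) and a 3.1-fold lower number from compound 1 to compound 3 (0.49 log units; beyond the scatter) both replace the pyridin-2-yl group and both move the number down, while a 1.7-fold higher number from compound 2 to compound 3 (0.23 log units; within the scatter) stays within the scatter. Among the measured compounds shown here, no measured step replaces the 3-methoxyphenyl group with another aryl group carrying a different substituent, so there is no direct guide for the 4-nitrophenyl group. Since the two non-pyridyl groups give numbers within the scatter of each other, the step is expected to be small, and a 1.1-fold lower number from compound 3 to compound 4 (0.04 log units; within the scatter) is expected to stay within the scatter. Compound 4 is thus estimated to give 10000 nM in this assay, with a range from 4000 nM to 28000 nM.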

Compound 4, half-maximal inhibitory concentration: 12400 nM
Estimate against measurement, compound 4: 1.2-fold (0.09 log units) below; low and high end bracket the measured number.
By their numbers in this assay, from the lowest: compounds 2, 3 and 4 (each within the scatter of the next); then compound 1.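

In this assay the 4-nitrophenyl group shows that exchanging one substituted phenyl ring for another at this place, on a double-bonded chain carbon bound to a double-bonded chain carbon, gives a 1.1-fold higher number from compound 3 to compound 4 (0.06 log units; within the scatter) and so no difference that can be read. With a 1.9-fold higher number from compound 2 to compound 4 (0.28 log units; within the scatter) as well, cyclohexyl, 3-methoxyphenyl and 4-nitrophenyl cannot be told apart in any pair, whereas a 2.7-fold lower number from compound 1 to compound 4 (0.44 log units; beyond the scatter) makes this the third replacement of pyridin-2-yl to give a lower number, with no listed compound going against that pattern. No measurement among these data accounts for why compound 1 stands apart from the other three compounds.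

The compounds shown leave open whether the pyridine ring nitrogen itself matters, which pyridin-3-yl, pyridin-4-yl or an unsubstituted phenyl group could test, and whether 4-methoxyphenyl or 3-nitrophenyl would separate the identity of the substituent from its ring position. They also leave open whether the same flat picture would hold for a phenyl ring carrying an amine or a carboxylic acid, or for a longer chain at this place.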